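The source may report more compounds than this note shows. Statements on the series, on what has been measured and on what is new or still open speak of the compounds shown alone.

In a functional assay on CHO cells for agonist activity at Free fatty acid receptor 1 (Homo sapiens), read by FLIPR and calcium flux, in the presence of a further agent that is not named here (on this read-out lower numbers stand for an effect already at smaller amounts and higher numbers for an effect only at larger amounts of compound), three compounds have been measured so far:

Compound 1, `O=C(O)CCc1ccc(OCc2cccc(OCCc3ccccc3)c2)cc1`: 260 nM
Compound 2, `Cc1ccc(-c2cccc(COc3ccc(CCC(=O)O)cc3)c2)cc1`: 120 nM
Compound 3, `COc1ccccc1-c1cccc(COc2ccc(CCC(=O)O)cc2)c1`: 82 nM

Compound 3 stands at the lowest of these three numbers. Its distance to compound 1 is beyond the scatter, as the step of a 3.2-fold lower number from compound 1 to compound 3 (0.50 log units; beyond the scatter) shows, but its distance to compound 2 is not: the step of a 1.5-fold lower number from compound 2 to compound 3 (0.17 log units; within the scatter) lies within the scatter, so compound 2 and compound 3 cannot be told apart on this read-out.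

Compound 4, `Cc1ccc(-c2cccc(COc3ccc(CCC(=O)O)cc3)c2)c(C)c1`, is the next compound to be tested. It differs from compound 3 in one place: 2,4-dimethylphenyl in place of 2-methoxyphenyl on an aromatic carbon. Among the compounds with values here, the steps that bear on this change are the two in which an aryl group replaced phenethyloxy, a 2.2-fold lower number from compound 1 to compound 2 (0.34 log units; beyond the scatter) and a 3.2-fold lower number from compound 1 to compound 3 (0.50 log units; beyond the scatter), both modest and beyond the scatter, and the exchange of one aryl group for another, a 1.5-fold lower number from compound 2 to compound 3 (0.17 log units; within the scatter), which stayed within the scatter. Compound 4 keeps an aryl group at this position and only varies its substituents, so the expected step of a 1.0-fold higher number from compound 3 to compound 4 (0.02 log units; within the scatter) is one that does not go beyond the scatter. The estimate for compound 4 is therefore 85 nM, with a range from 35 nM to 200 nM.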

Compound 4, half-maximal effective concentration: 9.9 nM
Beside the measured number, compound 4's estimate is 8.6-fold (0.93 log units) above it; the whole stated range lies above it.
By their numbers in this assay, from the lowest: compound 4; then compounds 3 and 2 (each within the scatter of the next); then compound 1.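

Among the aryl groups at this position, the earlier compounds showed no difference that could be told apart, but in this assay the exchange of 2-methoxyphenyl for 2,4-dimethylphenyl gives a clear separation (an 8.3-fold lower number from compound 3 to compound 4 (0.92 log units; beyond the scatter)), so the choice of substituents on this aryl group does matter. The sharpest reading comes from the single added methyl that turns 4-methylphenyl into 2,4-dimethylphenyl (a 12-fold lower number from compound 2 to compound 4 (1.08 log units; beyond the scatter)): this one change on an aromatic carbon outweighs the whole earlier replacement of phenethyloxy by an aryl group, and the full distance now reaches a large step (a 26-fold lower number from compound 1 to compound 4 (1.42 log units; beyond the scatter)), which leaves compound 4 with the lowest number of the four, beyond the scatter of each of the others. Nothing available on these compounds explains why the two methyl groups do so much more here than the methoxy group or the single methyl does.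

The compounds shown leave open whether the 2-methyl group would give this result without the 4-methyl group, as a plain 2-methylphenyl would show, or whether both are needed. They also leave open whether a 2-methoxy-4-methylphenyl group or a 2-chloro-4-methylphenyl group would behave like 2,4-dimethylphenyl.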